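Working notes: cyclohexyl to methyl, compound 3 to compound 4

A few compounds are considered here, and "the series" means these few. Any claim that something is new, unique, unknown or untested is made for them only; others in the source may bear on it.

In a functional assay on MCF7 cells (Homo sapiens) for inhibition, read by MTT assay, with a stated time of 96 h (on this read-out lower numbers stand for stronger inhibition of growth and higher numbers for weaker inhibition of growth), compound 1 `O=C(NCCCCCCSSCCCCCCNC(=O)c1cc(-c2ccncc2)n[nH]1)c1cc(-c2ccncc2)n[nH]1` gives 7150 nM and compound 2 `CCCC(=O)SCCCCCCNC(=O)c1cc(-c2ccncc2)n[nH]1` gives 12100 nM. Compound 3 `O=C(NCCCCCCS)c1cc(C2CCCCC2)n[nH]1` returns no number in this assay but only a limit, > 50000 nM. Compound 3 is the one of the three that sits at the boundary of the measurable range, (the limit of > 50000 nM in this assay, at which 1 of the 3 values shown sits), so its standing among the numbers cannot be placed more closely than that.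

Compound 4 `Cc1cc(C(=O)NCCCCCCS)[nH]n1` is the next entry. The change from compound 3 to compound 4 is methyl in place of cyclohexyl on an aromatic carbon.

Among the compounds with values here, no measured pair in the set shares this change, so the size and direction of the step cannot be read from the data. With compound 3 already at the limit, the working expectation is a step that the limit leaves unreadable from compound 3 to compound 4, meaning no movement that would be told apart from the scatter. Compound 4 is therefore estimated at 70000 nM, within a range from 20000 nM to 250000 nM, with a high chance that this assay again reports only a limit for compound 4.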

Compound 4, concentration for 50% growth inhibition: > 50000 nM
Compound 4: no number, only a limit; the forecaster's own chance of this, stated with the estimate: 75%; the middle value is on the limit's open side.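

Compound 3 and compound 4 both stand only as limits in this assay, so no step can be read between them: the limit of > 50000 nM in this assay, at which 2 of the 4 values shown sit.

The compounds shown leave open whether methyl and cyclohexyl on the shared core differ at all in this assay once a number replaces the limit.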